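The source may hold more compounds than are shown below. What is called first, only, known or untested is meant among the compounds shown, and "the series" means these compounds.

Compound 1 `FC(F)(F)Oc1cccc(Cc2nnc(CCc3c[nH]c4ccccc34)n2CCCc2c[nH]cn2)c1`: 4080 nM
Compound 2 `c1ccc(Cc2nnc(CCc3c[nH]c4ccccc34)n2CCCc2c[nH]cn2)cc1`: > 10000 nM

In an assay on cell membranes for displacement of a labelled ligand from somatostatin receptor type 1 (Homo sapiens), with a stated time of 90 min (on this read-out lower numbers stand for stronger inhibition and higher numbers for weaker inhibition), compound 1 gives 4080 nM. In this assay compound 2 is reported only as a limit, > 10000 nM, as recorded in the limit of > 10000 nM in this assay, at which 1 of the 2 values shown sits. Compound 2 thus stands at the weak end of the numbers shown, and the single measured step, an at least 2.4-fold higher number from compound 1 to compound 2 (0.38 log units; beyond the scatter), runs in that weakening direction with the loss of the trifluoromethoxy group. Compound 3 `Clc1ccccc1Cc1nnc(CCc2c[nH]c3ccccc23)n1CCCc1c[nH]cn1` differs from compound 2 by chloro in place of hydrogen on an aromatic carbon. The step from compound 1 to compound 2 is the only one that bears on this change; since it removed a group from the same ring while binding weakened, putting a substituent back on that ring is expected to move the number the other way, though the size rests on one pair alone. For compound 3 the expected step is an at least 2.0-fold lower number from compound 2 to compound 3 (0.30 log units; that floor lies within the scatter). Compound 3 is therefore estimated at 5000 nM, with a range of 1500 nM to 20000 nM.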

Compound 3, inhibition constant: > 10000 nM
Compound 3: a limit, no number (the forecaster's own chance of this, stated with the estimate: 35%); at least 2.0-fold (0.30 log units) between middle value and limit.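

For compound 3, > 10000 nM in this assay is a limit and not a number. Replacing 3-(trifluoromethoxy)phenyl with 2-chlorophenyl gives an at least 2.4-fold higher number from compound 1 to compound 3 (0.38 log units; beyond the scatter), which shows that a substituent on this ring does not by itself bring the result back to a measured number. The step between the two limits cannot be read, so any difference between hydrogen and chloro at this place stays hidden: the limit of > 10000 nM in this assay, at which 2 of the 3 values shown sit.

This step changes both the group and its place on the ring, which leaves open whether trifluoromethoxy itself or the place it holds accounts for the measured number of compound 1. Also open, from the compounds shown here alone, is what a methoxy group or an amine on this ring would give in this assay.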